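The source may hold more compounds than are shown below. What is called first, only, known or untested is meant among the compounds shown, and "the series" means these compounds.

Working notes on the series. Compound 1 `O=C(NCCCN1CCN(c2ccc(Br)cc2)CC1)NN(Cc1ccccc1)c1ccccc1` gives 14 nM in an assay on CHO cells for displacement of a labelled ligand from D(4) dopamine receptor (Homo sapiens), read by radioligand binding; on this read-out higher numbers stand for weaker inhibition and lower numbers for stronger inhibition. Compound 3 `O=C(NCCCN1CCN(c2ccc(I)cc2)CC1)NN(Cc1ccccc1)c1ccccc1` carries iodo in place of bromo on an aromatic carbon relative to compound 1; in this assay compound 3 gives 21 nM, and the step is a 1.5-fold higher number from compound 1 to compound 3 (0.18 log units; within the scatter). Compound 2 `O=C(NCCN1CCN(c2ccc(Br)cc2)CC1)NN(Cc1ccccc1)c1ccccc1` gives 28 nM in this assay; the difference between the core of compound 2 and the core of compound 1 is not broken down here, and the two values lie within the scatter of each other.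

Compound 4 `O=C(NCCN1CCN(c2ccc(I)cc2)CC1)NN(Cc1ccccc1)c1ccccc1` is not yet measured. It carries iodo in place of bromo on an aromatic carbon relative to compound 2, the same change as that made from compound 1 to compound 3, at a place described in the same words. In this assay the step to compound 4 is expected to be a 1.4-fold higher number from compound 2 to compound 4 (0.13 log units; within the scatter), resting on the earlier step of a 1.5-fold higher number from compound 1 to compound 3 (0.18 log units; within the scatter), which stayed within the scatter. Compound 4 is estimated at 38 nM, with a likely range from 15 nM to 95 nM.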

Compound 4, inhibition constant: 44 nM
Compound 4: the middle estimate sits 1.2-fold (0.06 log units) below what was measured, and the stated range covers the measured number.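

In this assay the change from 4-bromophenyl to 4-iodophenyl gives a 1.6-fold higher number from compound 2 to compound 4 (0.20 log units; within the scatter). Set beside the earlier step, the change reads alike on the two cores: the same change on two cores in this assay, a 1.5-fold higher number (0.18 log units; within the scatter) from compound 1 to compound 3 and a 1.6-fold higher number (0.20 log units; within the scatter) from compound 2 to compound 4, 1.0-fold (0.02 log units) apart, within the scatter of two such steps. This shows that, on these two cores, the swap carries over with no difference beyond the scatter; it does not show that the swap shifts the number at all, as each step stays within the scatter, and two cores cannot speak for the whole series.

The compounds shown leave open how chloro, fluoro or methoxy would read at the same place on the aromatic ring. They also leave open whether the swap carries over on a longer chain than that of compound 1.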